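The compounds below may be only part of what the source reports. "The series", "measured", "known", "first", "only" and "open" are said of these compounds alone.

In a functional assay on HL-60 cells (Homo sapiens) for cytotoxicity, read by ELISA, with a stated time of 2 days (on this read-out lower numbers stand for stronger inhibition and higher numbers for weaker inhibition), three compounds have been measured so far. Compound 1 (`Oc1cccc(-c2cc(-c3ccccc3)cc(-c3ccccc3)n2)c1`) gives 11500 nM, compound 2 (`Oc1cccc(-c2cc(-c3ccccc3)cc(-c3ccncc3)n2)c1`) gives 23900 nM, and compound 3 (`Oc1ccc(-c2cc(-c3ccccc3)cc(-c3ccccc3)n2)cc1`) gives 1400 nM, the lowest number of the three. The unmeasured compound 4 (`Oc1ccc(-c2cc(-c3ccccc3)cc(-c3ccco3)n2)cc1`) differs from compound 3 by furan-2-yl in place of phenyl on an aromatic carbon, next to the ring nitrogen: furan-2-yl in place of phenyl on an aromatic carbon. Going by the values given here, no furan-2-yl compound has been measured yet. Among the compounds with values here, the nearest precedent is another replacement of phenyl, by pyridin-4-yl, which gave a modest step, a 2.1-fold higher number from compound 1 to compound 2 (0.32 log units; beyond the scatter). That step was seen on the core of compound 1, which lacks the 4-hydroxyphenyl group, and the other measured step, an 8.2-fold lower number from compound 1 to compound 3 (0.91 log units; beyond the scatter), shows that the hydroxyphenyl group alone can shift the number considerably. The precedent therefore carries over only loosely. A modest rise is expected in this assay, with an estimated step of a 1.8-fold higher number from compound 3 to compound 4 (0.25 log units; within the scatter). For compound 4 the estimated value is 2500 nM, with an expected range of 700 nM to 9000 nM.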

Compound 4, half-maximal inhibitory concentration: 3300 nM
The estimate for compound 4 lay 1.3-fold (0.12 log units) below the measured number; the measured number falls inside the stated range.
By their numbers in this assay, from the lowest: compound 3; then compound 4; then compound 1; then compound 2.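

In this assay, furan-2-yl in place of phenyl next to the ring nitrogen gives a 2.4-fold higher number from compound 3 to compound 4 (0.37 log units; beyond the scatter) and so raises the number beyond the scatter on the core that carries the 4-hydroxyphenyl group. The one earlier replacement of this kind, pyridin-4-yl for phenyl on the core of compound 1, gave a 2.1-fold higher number from compound 1 to compound 2 (0.32 log units; beyond the scatter) and went the same way, so two different incoming rings, on two different cores, now both raise the number. No measurement at hand explains why the number rises with either ring.

Going by these compounds, it remains open whether pyridin-4-yl would give a similar step on the core of compound 3. On these data alone, it is also open how a non-aromatic group in this place, such as a morpholine ring or a simple amine, would compare with phenyl.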